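Swapping thiophen-2-yl for 4-chlorophenyl: solubility expected for compound 4

The source may report more compounds than this note shows. Statements on the series, on what has been measured and on what is new or still open speak of the compounds shown alone.

Measured compounds:
compound 1, `CCOC(=O)c1c(-c2cccc(Cl)c2)[nH]c2cccc(OC)c2c1=O`: > 100000 nM
compound 2, `CCOC(=O)c1c(-c2cccc(C(F)(F)F)c2)[nH]c2cc(OC)ccc2c1=O`: 19000 nM
compound 3, `CCOC(=O)c1c(-c2cccs2)[nH]c2cc(OC)ccc2c1=O`: > 100000 nM

Compound 3 `CCOC(=O)c1c(-c2cccs2)[nH]c2cc(OC)ccc2c1=O` was tested in a physicochemical assay for solubility, in phosphate buffer, at pH 7.4; on this read-out higher numbers stand for higher solubility and lower numbers for lower solubility. For compound 3 the result is not a number but a limit of the assay, > 100000 nM. Compound 1 likewise returns a limit, > 100000 nM. Compound 2 is the only one of the three with a number, 19000 nM; two of the three results sit at the limit of > 100000 nM in this assay, at which 2 of the 3 values shown sit, so compound 3 stands at the upper edge of what this assay reports.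

Compound 4 `CCOC(=O)c1c(-c2ccc(Cl)cc2)[nH]c2cc(OC)ccc2c1=O` is not yet measured in this assay. It differs from compound 3 by 4-chlorophenyl in place of thiophen-2-yl on an aromatic carbon. For the measured compounds named here, no step between two measured compounds describes this exchange, so the expectation rests only on the values shown. For compound 4 a step beyond the usual scatter is expected, downward, an at least 2.5-fold lower number from compound 3 to compound 4 (0.39 log units; beyond the scatter). Compound 4 is therefore estimated at 40000 nM, within a range from 10000 nM to 100000 nM.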

Compound 4, solubility: 3000 nM
Beside the measured number, compound 4's estimate is 13-fold (1.12 log units) above it, outside the stated range (below it).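

In this assay, the group on this aromatic carbon, next to the ring nitrogen and ortho to the ethoxycarbonyl group, proves decisive: 4-chlorophenyl in place of thiophen-2-yl gives an at least 33-fold lower number from compound 3 to compound 4 (1.52 log units; beyond the scatter). For the compounds shown here, no earlier pair differed in one place, so this is the first single change that can be read on the shared core, and it shows that this position alone can carry a large drop. Because compound 3 stands at a limit, the step gives only a minimum size: the limit of > 100000 nM in this assay, at which 2 of the 4 values shown sit.

The compounds shown leave open whether the drop goes with the chlorine or with the six-membered ring itself, a question that plain phenyl at this position would settle. They also leave open how an aminomethyl-bearing phenyl here, or a carboxylic acid in place of the ethoxycarbonyl group, would stand in this assay.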